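The source may report more compounds than this note shows. Statements on the series, on what has been measured and on what is new or still open speak of the compounds shown alone.

In a functional assay on HT-29 cells (Homo sapiens) for antiproliferative activity (a higher number here means a weaker inhibitor, a lower number a stronger inhibitor), compound 1 `COc1ccc(Nc2cccc3c2N(S(=O)(=O)c2ccc(OC)cc2)CC3)cc1` gives 803 nM and compound 2 `COc1ccc(S(=O)(=O)N2CCc3cccc(Nc4ccc(F)cc4)c32)cc1` gives 588 nM while compound 3 `COc1ccc(S(=O)(=O)N2CCc3cccc(Nc4ccc(C#N)cc4)c32)cc1` gives 149 nM as the lowest of the three numbers. Compound 4 `COC(=O)c1ccc(Nc2cccc3c2N(S(=O)(=O)c2ccc(OC)cc2)CC3)cc1` has methoxycarbonyl in place of cyano on an aromatic carbon, para to a large group (methoxycarbonyl in place of cyano on an aromatic carbon). Three measured steps at this place bear on the change. Fluoro for methoxy stays within the scatter (a 1.4-fold lower number from compound 1 to compound 2 (0.14 log units; within the scatter)), whereas cyano for methoxy (a 5.4-fold lower number from compound 1 to compound 3 (0.73 log units; beyond the scatter)) and cyano for fluoro (a 3.9-fold lower number from compound 2 to compound 3 (0.60 log units; beyond the scatter)) are modest. Among the measured compounds shown here, no measured compound holds methoxycarbonyl, but removing cyano is expected to raise the number modestly (a 2.2-fold higher number from compound 3 to compound 4 (0.35 log units; beyond the scatter)). Compound 4 is therefore estimated at 330 nM (expected range 120 nM to 900 nM).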

Compound 4, half-maximal inhibitory concentration: 678 nM
Compound 4: middle estimate off by 2.1-fold (0.31 log units), on the low side; the measured number falls inside the stated range.
By their numbers in this assay, from the lowest: compound 3; then compounds 2, 4 and 1 (each within the scatter of the next).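

At this place on the ring, methoxycarbonyl does not keep the low number that cyano gives in this assay (a 4.6-fold higher number from compound 3 to compound 4 (0.66 log units; beyond the scatter)). Against the other two groups, methoxycarbonyl stays within the scatter (a 1.2-fold higher number from compound 2 to compound 4 (0.06 log units; within the scatter); a 1.2-fold lower number from compound 1 to compound 4 (0.07 log units; within the scatter)), so among these four compounds only the cyano compound stands apart, with methoxycarbonyl, fluoro and methoxy reading alike. No measurement shown here explains this separation. Going by these compounds, whether a carboxylic acid, a primary amide or an amine at this place would join cyano or the other three remains open.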